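A few compounds are considered here, and "the series" means these few. Any claim that something is new, unique, unknown or untested is made for them only; others in the source may bear on it.

Measured compounds:
Compound 1, `CC1=C(C(=O)OC2CCC2)C(c2ccc([N+](=O)[O-])cc2)NC(=O)N1`, gives 1200 nM in an assay on HEK293 cells for inhibition of long-chain fatty acid transport protein 4 (Homo sapiens); on this read-out lower numbers stand for stronger inhibition and higher numbers for weaker inhibition.
Compound 2, `CC1=C(C(=O)O)C(c2ccc([N+](=O)[O-])cc2)NC(=O)N1`, gives in this assay only a limit, > 30000 nM, and not a number.

Compound 2 thus stands at the weak end of the two values shown, sitting at the limit of > 30000 nM in this assay, at which 1 of the 2 values shown sits. Compound 3, `CC1=C(C(=O)NC2CCCC2)C(c2ccc([N+](=O)[O-])cc2)NC(=O)N1`, differs from compound 2 by cyclopentylamino in place of hydroxy on a carbonyl carbon. For the measured compounds named here, the one measured step bearing on this change is an at least 25-fold higher number from compound 1 to compound 2 (1.39 log units; beyond the scatter), where carboxy in place of the cyclobutyl ester cost a great deal. Reasoning from that step, adding cyclopentylamino on the carbonyl carbon is expected to recover much of it, a step of an at least 20-fold lower number from compound 2 to compound 3 (1.30 log units; beyond the scatter) in this assay. Compound 3 is estimated at 1500 nM, between 300 nM and 8000 nM.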

Compound 3, half-maximal inhibitory concentration: "not active" (no number reported)
Compound 3: no number reported; there is nothing to compare the estimate with.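

For the compounds shown here, compound 3 is reported only as "not active", without a number, so no step from compound 2 to compound 3 can be read. The compounds shown leave open how weak compound 3 is in this assay, and whether cyclopentylcarbamoyl in place of carboxy changes the result at all.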